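Cyclobutyl for Methyl on the Carbonyl of Compound 2

The compounds below may be only part of what the source reports. "The series", "measured", "known", "first", "only" and "open" are said of these compounds alone.

Compound 1 `Cc1[nH]nc(N)c1-c1cccc(C(F)(F)F)c1` gives > 100000 nM in an assay on Sf9 cells for inhibition of inhibitor of nuclear factor kappa-B kinase subunit epsilon (Homo sapiens), read by ADP-Glo, with a stated time of 60 min (a higher number here means a weaker inhibitor, a lower number a stronger inhibitor), which is a limit of the assay and not a number.
Compound 2 `CC(=O)n1nc(C)c(-c2ccc(Cl)c(Cl)c2)c1N` gives > 100000 nM in this assay, again only a limit.

Compound 2 thus stands at the limit of > 100000 nM in this assay, at which 2 of the 2 values shown sit, so no number is known for it. Compound 3 `Cc1nn(C(=O)C2CCC2)c(N)c1-c1ccc(Cl)c(Cl)c1` differs from compound 2 by cyclobutyl in place of methyl on a carbonyl carbon. Among the measured compounds shown here, no measured step of this kind exists here, so in this assay no shift beyond the usual scatter is expected. Compound 3 is expected to give about 150000 nM, between 30000 nM and 800000 nM. The expected change amounts to a step that the limit leaves unreadable from compound 2 to compound 3, within the scatter.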

Compound 3, half-maximal inhibitory concentration: > 100000 nM
Compound 3 ended at the assay's limit; the forecaster's own chance of this, stated with the estimate: 80%; the middle value lies beyond the limit too.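

Compound 2 and compound 3 both end at a limit of the assay rather than at a number, so no step between them can be read: the limit of > 100000 nM in this assay, at which 3 of the 3 values shown sit.

The compounds shown leave open what change to the shared core, if any, would give a measurable value in this assay.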